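The compounds below may be only part of what the source reports. "The series", "measured", "known", "first", "only" and "open" are said of these compounds alone.

Compound 1, with the structure `CCCCCCCCCCCCNC(=O)[C@@H](NC(=O)c1cc2ccccc2o1)[C@@H](C)O`, is the reference point of this small series. In a functional assay on SW-620 cells (Homo sapiens) for cytotoxicity, read by MTT assay, with a stated time of 48 h (a higher number here means a weaker inhibitor, a lower number a stronger inhibitor), compound 1 gives 21300 nM. Compound 2, whose structure is `CCCCCCCCCCCCNC(=O)[C@@H](NC(=O)c1nccc2ccccc12)[C@@H](C)O`, differs from it in one place: isoquinolin-1-yl in place of 1-benzofuran-2-yl on a carbonyl carbon. That change brought a 3.1-fold higher number from compound 1 to compound 2 (0.49 log units; beyond the scatter). Compound 3, with the structure `CCCCCCCCCCCCCCNC(=O)[C@@H](NC(=O)c1cc2ccccc2o1)[C@@H](C)O`, keeps the core of compound 1 but carries a longer chain; the counted difference is ethyl in place of hydrogen on a saturated chain carbon, ten or more bonds along the chain from an amide-type nitrogen. In this assay compound 3 gives 26700 nM, a step of a 1.3-fold higher number from compound 1 to compound 3 (0.10 log units; within the scatter), so the longer chain left the result essentially where it was. Compound 2 in this assay gives 65800 nM.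

Compound 4, whose structure is `CCCCCCCCCCCCCCNC(=O)[C@@H](NC(=O)c1nccc2ccccc12)[C@@H](C)O`, has not yet been measured in this assay. It stands to compound 3 as compound 2 stands to compound 1: isoquinolin-1-yl in place of 1-benzofuran-2-yl on a carbonyl carbon. The place of the change is described in the same words for both pairs, so this is the same change made on the longer-chain core. Since the chain extension itself changed little, as a 1.3-fold higher number from compound 1 to compound 3 (0.10 log units; within the scatter) shows, the most reasonable expectation is that the ring exchange will repeat its earlier effect, and a step of a 3.0-fold higher number from compound 3 to compound 4 (0.48 log units; beyond the scatter) is therefore expected. On that basis compound 4 is estimated at 80000 nM, with a plausible range from 40000 nM to 160000 nM. For the measured compounds named here, with only one prior instance of this exchange, the expectation rests on a single step and remains open to revision.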

Compound 4, half-maximal inhibitory concentration: 30400 nM
Beside the measured number, compound 4's estimate is 2.6-fold (0.42 log units) above it, outside the stated range (below it).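

In this assay, isoquinolin-1-yl in place of 1-benzofuran-2-yl on the longer-chain core gave a 1.1-fold higher number from compound 3 to compound 4 (0.06 log units; within the scatter), so the change did not carry over from the shorter-chain core with the size it had there: the same change on two cores in this assay, a 3.1-fold higher number (0.49 log units; beyond the scatter) from compound 1 to compound 2 and a 1.1-fold higher number (0.06 log units; within the scatter) from compound 3 to compound 4, 2.7-fold (0.43 log units) apart, beyond the scatter of two such steps Read along the other edge of the same four compounds, the longer chain on the isoquinolin-1-yl core gave a 2.2-fold lower number from compound 2 to compound 4 (0.34 log units; beyond the scatter), whereas on the 1-benzofuran-2-yl core it had made no change beyond the scatter: the same change on two cores in this assay, a 1.3-fold higher number (0.10 log units; within the scatter) from compound 1 to compound 3 and a 2.2-fold lower number (0.34 log units; beyond the scatter) from compound 2 to compound 4, 2.7-fold (0.43 log units) apart, beyond the scatter of two such steps These two comparisons show that, among these four compounds, the effect of each change depends on the group present at the other place, so a step taken on one core could not simply be transferred to the other, but they do not show why this happens, and with one pair per comparison they do not show whether the same dependence extends beyond these compounds.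

The compounds shown leave open how the two ring groups would compare on a shorter chain or a still longer chain, and so whether the gap between them closes steadily as the chain grows or only at this one length. They also leave open whether another ring group on the carbonyl carbon, such as quinolin-2-yl or indol-2-yl, would follow compound 2 and compound 4 or the 1-benzofuran-2-yl pair.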